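Benzyl in Place of Isopropyl on an Inactive Bromochromone

The source may report more compounds than this note shows. Statements on the series, on what has been measured and on what is new or still open speak of the compounds shown alone.

Measured compounds:
compound 1 `CCc1cc(=O)c2ccc(OCc3ccccc3)c(C)c2o1`: > 33900 nM
compound 2 `CCc1oc2c(C)c(OC(C)C)ccc2c(=O)c1Br`: > 30700 nM

In a functional assay on A549 cells (Homo sapiens) for antiproliferative activity, read by sulforhodamine B assay, with a stated time of 72 h (on this read-out lower numbers stand for stronger inhibition of growth and higher numbers for weaker inhibition of growth), compound 1 gives no number, only the limit of the assay, > 33900 nM. In this assay compound 2 likewise stops at the limit, > 30700 nM. Compound 2 thus stands where every value shown stands, at a limit (the limit of > 30700 nM in this assay, at which 1 of the 2 values shown sits), and compound 1 sits at its own limit (the limit of > 33900 nM in this assay, at which 1 of the 2 values shown sits). For the measured compounds named here, no step between the two is given; together the two values show only that neither compound inhibits growth within the measurable range.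

Compound 3 `CCc1oc2c(C)c(OCc3ccccc3)ccc2c(=O)c1Br` differs from compound 2 in one place: benzyl in place of isopropyl on an oxygen on an aromatic ring. Going by the values given here, no measured step in the data resembles this change, so the expectation rests on compound 2 alone, whose value > 30700 nM is a limit. The estimated step that the limit leaves unreadable from compound 2 to compound 3 is expected to be none beyond the scatter. For compound 3 the estimate in this assay is 35000 nM, within a range from 15000 nM to 80000 nM, most likely returned again as a limit rather than a number.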

Compound 3, concentration for 50% growth inhibition: > 26700 nM
Compound 3: only a limit was reported (the forecaster's own chance of this, stated with the estimate: 85%); the middle value does not contradict the limit.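

In this assay compound 3 also gives only a limit, > 26700 nM, so its steps from compound 1 and compound 2 cannot be read. The compounds shown leave open whether either change would alter growth inhibition in a compound with a measurable value.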